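Aryl swap on the shared core: compound 1 to compound 3

The source may report more compounds than this note shows. Statements on the series, on what has been measured and on what is new or still open speak of the compounds shown alone.

Measured so far:
compound 1 `COc1ccccc1C1CC(c2cc(OC)c(OC)c(OC)c2)=NN1C(C)=O` — > 100000 nM
compound 2 `COc1ccc(C2CC(c3cc(OC)c(OC)c(OC)c3)=NN2)cc1OC` — 44000 nM

In a functional assay on B16 cells (Mus musculus) for cytotoxicity, read by MTT assay, with a stated time of 72 h (a lower number here means a stronger inhibitor, a higher number a weaker inhibitor), compound 1 gives only a limit of the assay, > 100000 nM, which is the limit of > 100000 nM in this assay, at which 1 of the 2 values shown sits. Compound 2 gives 44000 nM in this assay. Among the compounds with values here, no two measured compounds differ in a single place, so no measured step is available. Compound 3 `COc1ccc(C2CC(c3cc(OC)c(OC)c(OC)c3)=NN2C(C)=O)cc1O` differs from compound 1 by 3-hydroxy-4-methoxyphenyl in place of 2-methoxyphenyl on a saturated ring carbon. For compound 3 the step from compound 1 to compound 3 is expected to be an at least 3.3-fold lower number from compound 1 to compound 3 (0.52 log units; beyond the scatter), toward stronger inhibition, with a real chance that only a limit is again reported. Compound 3 is estimated at 30000 nM, within 3000 nM to 150000 nM.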

Compound 3, half-maximal inhibitory concentration: > 100000 nM
Compound 3: only a limit was reported (the forecaster's own chance of this, stated with the estimate: 35%); middle value at least 3.3-fold (0.52 log units) away from the limit.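

Compound 1 and compound 3 both give only a limit in this assay, and no step can be read between them: the limit of > 100000 nM in this assay, at which 2 of the 3 values shown sit.

Going by these compounds, whether 3-hydroxy-4-methoxyphenyl in place of 2-methoxyphenyl on the shared core changes the read-out at all remains open.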